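The source may hold more compounds than are shown below. What is called first, only, known or untested is meant among the compounds shown, and "the series" means these compounds.

For the measured compounds named here, in a physicochemical assay for lipophilicity, read by HPLC (a lower number here means a more polar compound, a higher number a more lipophilic compound), only two compounds have been read so far. Compound 1 `COC(=O)C1(c2ccc(NC(=O)Nc3cccnc3Oc3ccccc3C(C)(C)C)cc2)CC1` gives 5.1, while compound 2 `CC(C)(C)c1ccccc1Oc1ncccc1NC(=O)Nc1ccc(C2(CO)CC2)cc1` gives 4.6, the lower of the two numbers. Compound 3 `CC(C)(C)c1ccccc1Oc1ncccc1NC(=O)Nc1ccc(N2CCCCC2)cc1` has no reading yet.

The change from compound 2 is piperidin-1-yl in place of 1-(hydroxymethyl)cyclopropyl on an aromatic carbon, para to a large group. Going by the values given here, one measured step bears on this, and only indirectly: a number 0.50 log units lower from compound 1 to compound 2 (beyond the scatter), a modest step beyond the scatter, with hydroxymethyl in place of methoxycarbonyl on a saturated ring carbon. Among the compounds with values here, it concerns the same substituent, but no measured compound carries piperidin-1-yl, so the data offer no direct precedent.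

Within the data shown here, the hydroxymethyl group leaves in the new change, and the one step that introduced it went downward, so a move back up in this assay is expected. The expected step is a number 0.70 log units higher from compound 2 to compound 3 (beyond the scatter), somewhat larger than the measured one and uncertain in size. For compound 3 the estimated value is 5.3, with an expected range from 4.8 to 5.8.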

Compound 3, partition coefficient: 5.5
For compound 3 the middle estimate is 0.20 log units below the measured one; low and high end bracket the measured number.
By their numbers in this assay, from the lowest: compound 2; then compound 1; then compound 3.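

In this assay, the aromatic carbon para to a large group tolerates replacement of the whole substituent, not only the edit on the saturated ring carbon seen earlier: piperidin-1-yl in place of 1-(hydroxymethyl)cyclopropyl gives a number 0.90 log units higher from compound 2 to compound 3 (beyond the scatter), a step larger than the one that separated the two earlier compounds. The same group in place of 1-(methoxycarbonyl)cyclopropyl gives a number 0.40 log units higher from compound 1 to compound 3 (beyond the scatter), so compound 3 stands above both earlier compounds, with each step beyond the scatter, and the top of the series no longer belongs to the ester-bearing compound. No measurement at hand accounts for either step.

Because the change removes the three-membered carbon ring and the hydroxymethyl group together and also brings in a ring nitrogen, the three compounds cannot assign the rise to any one of these features. A morpholine or a cyclohexyl group at this aromatic carbon, or a carboxylic acid on the saturated ring carbon, would show how far the readings in this series extend in either direction.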